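Estimating compound 3 from two measured neighbours

A few compounds are considered here, and "the series" means these few. Any claim that something is new, unique, unknown or untested is made for them only; others in the source may bear on it.

Within the data shown here, in a functional assay on MCF7 cells (Homo sapiens) for cytotoxicity, read by MTT assay, with a stated time of 72 h (a higher number here means a weaker inhibitor, a lower number a stronger inhibitor), compound 1 `O=C(/C=C/c1cc(Br)c(O)c(Br)c1)Nc1cc2c(Nc3ccc(F)c(Cl)c3)ncnc2cc1O[C@H]1CCOC1` gives 30600 nM, and compound 2 `O=C(/C=C/c1ccccc1[N+](=O)[O-])Nc1cc2c(Nc3ccc(F)c(Cl)c3)ncnc2cc1O[C@H]1CCOC1` gives 28400 nM, so compound 2 stands level with its only measured neighbour. Compound 3 `COc1cc(/C=C/C(=O)Nc2cc3c(Nc4ccc(F)c(Cl)c4)ncnc3cc2O[C@H]2CCOC2)cc(OC)c1O` keeps the shared core and changes one group: 4-hydroxy-3,5-dimethoxyphenyl in place of 2-nitrophenyl on a double-bonded chain carbon bound to a double-bonded chain carbon. Among the measured compounds shown here, the one measured step that bears on this, a 1.1-fold lower number from compound 1 to compound 2 (0.03 log units; within the scatter), exchanged two different groups at the same place and stayed within the scatter. On that evidence, no step beyond the scatter is expected in this assay. Compound 3 is estimated at 29000 nM, with an expected range of 15000 nM to 55000 nM. This estimate means an expected 1.0-fold higher number from compound 2 to compound 3 (0.01 log units; within the scatter).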

Compound 3, half-maximal inhibitory concentration: 30500 nM
Estimate against measurement, compound 3: 1.1-fold (0.02 log units) below; the range from low to high includes it.
By their numbers in this assay, from the lowest: compounds 2, 3 and 1 (each within the scatter of the next).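

In this assay, a further substituted phenyl at this place again leaves the number where it was: a 1.1-fold higher number from compound 2 to compound 3 (0.03 log units; within the scatter), and a 1.0-fold lower number from compound 1 to compound 3 (0.00 log units; within the scatter). So 4-hydroxy-3,5-dimethoxyphenyl reads level with both 2-nitrophenyl and 3,5-dibromo-4-hydroxyphenyl, and these three substituted phenyl groups do not separate the compounds in this assay. Nothing measured here explains why the three read alike. The compounds shown leave open whether a group that is not a phenyl ring, such as an amine or a carboxylic acid, would shift the number at this place.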